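Methoxy to hydroxy: following compound 2 to compound 3

A few compounds are considered here, and "the series" means these few. Any claim that something is new, unique, unknown or untested is made for them only; others in the source may bear on it.

In a functional assay on Lewis lung carcinoma cells (Mus musculus) for antiproliferative activity, read by MTT assay, with a stated time of 24 h (a lower number here means a stronger inhibitor, a higher number a weaker inhibitor), compound 1 `C=CCc1cc(-c2cccc(C(F)(F)F)c2)ccc1O` gives 65900 nM. Compound 2 `C=CCc1cc(-c2cccc([N+](=O)[O-])c2)ccc1OC` stands only at a limit of this assay, > 100000 nM. Compound 3 `C=CCc1cc(-c2cccc([N+](=O)[O-])c2)ccc1O` differs from compound 2 by one change, hydrogen in place of methyl on an oxygen on an aromatic ring, or methoxy to hydroxy. Among the measured compounds shown here, no measured pair shows this change. However, compound 1 also carries hydroxy and gives 65900 nM, so a small gain in potency is expected, perhaps no larger than the scatter. The expected step is an at least 1.6-fold lower number from compound 2 to compound 3 (0.22 log units; that floor lies within the scatter). Compound 3 is estimated at 60000 nM, with an expected range from 25000 nM to 100000 nM.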

Compound 3, half-maximal inhibitory concentration: > 100000 nM
Compound 3 gave a limit, no number; the forecaster's own chance of this, stated with the estimate: 30%; middle value at least 1.6-fold (0.22 log units) from the limit.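

In this assay, compound 3 stands only at a limit, > 100000 nM. Both limits leave the methoxy to hydroxy step unreadable, and hydroxy on the nitro compound still yields no measured number. Nitro in place of trifluoromethyl on an aromatic carbon, with hydroxy kept, gives an at least 1.5-fold higher number from compound 1 to compound 3 (0.18 log units; that floor lies within the scatter), so this pair sets no firm order between the two groups.

From the compounds shown here alone, how far compound 2 and compound 3 lie past the limit stays open: the limit of > 100000 nM in this assay, at which 2 of the 3 values shown sit. Also open is whether an amine or a carboxylic acid in place of nitro would give a number in this assay.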